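A few compounds are considered here, and "the series" means these few. Any claim that something is new, unique, unknown or untested is made for them only; others in the source may bear on it.

Three close relatives built on one shared core are considered here. Compound 1 `C[Se]c1nc([Se]C)c2cccnc2n1` carries two methylseleno groups; in a functional assay on HT-29 cells (Homo sapiens) for cytotoxicity, read by MTT assay, with a stated time of 72 h (a lower number here means a stronger inhibitor of growth, a higher number a weaker inhibitor of growth), compound 1 gives "not determined" (no result reported), so no number is in hand for it. Compound 2 `CCCCC[Se]c1nc(N)c2cccnc2n1` carries an amino group together with a pentylseleno group, and in this assay compound 2 gives 5910 nM. Going by the values given here, this is the only number in hand, so compound 2 can be called neither strong nor weak against anything measured, and compound 1 offers no figure to set beside it. Compound 3 `C[Se]c1nc(N)c2cccnc2n1` keeps the amino group and differs in one place: hydrogen in place of butyl on a saturated chain carbon bound to a selenium atom, which read one bond further out is pentyl in place of methyl. Among the compounds with values here, no measured pair shows what such a shortening does in this assay, so the expectation rests on the change alone. The change is expected to cost a modest amount of potency, a 1.5-fold higher number from compound 2 to compound 3 (0.18 log units; within the scatter), roughly at the edge of the usual scatter. Compound 3 is therefore expected to give about 9000 nM in this assay, with a plausible range from 3000 nM to 30000 nM.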

Compound 3, concentration for 50% growth inhibition: 44100 nM
For compound 3 the middle estimate is 4.9-fold (0.69 log units) below the measured one; the measured number lies above the stated range.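

In this assay the step is a 7.5-fold higher number from compound 2 to compound 3 (0.87 log units; beyond the scatter), so replacing pentyl with methyl weakens growth inhibition by more than ordinary repeat-to-repeat variation, with the amino group and the shared core left unchanged. This single pair shows that the group on selenium is not a passive part of these molecules: in this assay, activity responds to a change on the saturated chain carbon bound to a selenium atom, and the longer of the two chains goes with the stronger inhibition. The data shown offer no evidence on why the shorter chain does worse.

Going by these compounds, with only pentyl and methyl to compare, the shape of the trend remains open: a propyl chain could fall anywhere between them, and a longer chain such as octyl could either strengthen or weaken growth inhibition, while a benzyl group would test something other than chain length. Compound 1 gives "not determined" (no result reported) in this assay and cannot be set against compound 3, which leaves the part played by the amino group open as well.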